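Swapping Ethyl for Phenyl on an Amide-Type Nitrogen

The source may hold more compounds than are shown below. What is called first, only, known or untested is meant among the compounds shown, and "the series" means these compounds.

In an ADME assay on Ava5 cells (Homo sapiens) for cytotoxicity (on this read-out lower numbers stand for higher toxicity in this test and higher numbers for lower toxicity in this test), compound 1 `NC(=S)Nc1cccc(OCCCCCc2ccccc2)c1` gives 22000 nM. Compound 2 `CCNC(=S)Nc1cccc(OCCCCCc2ccccc2)c1` reaches only a limit of this assay, > 50000 nM. The step of an at least 2.2-fold higher number from compound 1 to compound 2 (0.35 log units; beyond the scatter) is therefore known only in part, as the limit of > 50000 nM in this assay, at which 1 of the 2 values shown sits, shows. Compound 3 `S=C(Nc1ccccc1)Nc1cccc(OCCCCCc2ccccc2)c1` differs from compound 2 by phenyl in place of ethyl on an amide-type nitrogen. For the measured compounds named here, no measured step exchanges one carbon group for another on this nitrogen, so the single measured step offers no direct guide. A step of an at least 1.2-fold lower number from compound 2 to compound 3 (0.09 log units; that floor lies within the scatter) is expected, which stays within the scatter. Compound 3 is thus estimated at 40000 nM, with a range from 15000 nM to 100000 nM.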

Compound 3, half-maximal cytotoxic concentration: 35000 nM
Compound 3: the middle estimate sits 1.1-fold (0.06 log units) above what was measured; the range from low to high includes it.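

In this assay, phenyl on this amide-type nitrogen gives a 1.6-fold higher number from compound 1 to compound 3 (0.20 log units; within the scatter), so the aromatic ring leaves no clear difference from plain hydrogen. Against ethyl the change is an at least 1.4-fold lower number from compound 2 to compound 3 (0.15 log units; that floor lies within the scatter). Compound 2 stands at a limit, so the true size of that step stays unknown: the limit of > 50000 nM in this assay, at which 1 of the 3 values shown sits.

Going by these compounds, whether a longer chain on this nitrogen would move the number beyond the scatter remains open. So does the effect of an amine or a carboxylic acid on the new phenyl ring.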